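Replacing a Cyano Carbamate with a Fluorinated Amide

A few compounds are considered here, and "the series" means these few. Any claim that something is new, unique, unknown or untested is made for them only; others in the source may bear on it.

Measured compounds:
compound 1, `Cc1nc(S(C)(=O)=O)ccc1Oc1ncnc(OC2CCN(C(=O)OC(C)(C)C#N)CC2)c1F`, 92.9 nM
compound 2, `Cc1nc(S(C)(=O)=O)ccc1Oc1ncnc(OC2CCN(C(=O)OC(C)(C)CF)CC2)c1F`, 19.9 nM
compound 3, `Cc1nc(S(C)(=O)=O)ccc1Oc1ncnc(OC2CCN(C(=O)O[C@@H](C)CF)CC2)c1F`, 186 nM

In a functional assay on isolated protein for inhibition of Glucose-dependent insulinotropic receptor (Homo sapiens), read by HTRF and cAMP accumulation (on this read-out lower numbers stand for an effect already at smaller amounts and higher numbers for an effect only at larger amounts of compound), compound 1 gives 92.9 nM, the second highest of the three numbers. Compound 2 sits furthest from it, with a 4.7-fold lower number from compound 1 to compound 2 (0.67 log units; beyond the scatter); compound 3 sits nearest, with a 2.0-fold higher number from compound 1 to compound 3 (0.30 log units; within the scatter). Between compound 2 and compound 3 there is a 9.3-fold higher number from compound 2 to compound 3 (0.97 log units; beyond the scatter).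

Compound 4, `Cc1nc(S(C)(=O)=O)ccc1Oc1ncnc(OC2CCN(C(=O)C(C)(C)F)CC2)c1F`, has not yet been measured. Compared with compound 1 it carries this change: 1-fluoro-1-methylethyl in place of 1-cyano-1-methylethoxy on a carbonyl carbon. Within the data shown here, of the measured steps only the one from compound 1 to compound 2 bears on it, because there a 4.7-fold lower number from compound 1 to compound 2 (0.67 log units; beyond the scatter) accompanies the exchange of cyano for a fluorine-bearing group. Among the measured compounds shown here, the loss of the oxygen on the carbonyl carbon is covered by no measured pair, so that part of the change is unknown. On this basis a modest step to a lower number is expected, a 2.3-fold lower number from compound 1 to compound 4 (0.37 log units; beyond the scatter), with a wide range. Compound 4 is therefore estimated to give 40 nM in this assay, between 12 nM and 150 nM.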

Compound 4, half-maximal effective concentration: 76.3 nM
The estimate for compound 4 lay 1.9-fold (0.28 log units) below the measured number, within the range that was stated.
By their numbers in this assay, from the lowest: compound 2; then compounds 4, 1 and 3 (each within the scatter of the next, the first and the last beyond it).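

In this assay, the change from (1-cyano-1-methylethoxy)carbonyl to (1-fluoro-1-methylethyl)carbonyl gives a 1.2-fold lower number from compound 1 to compound 4 (0.09 log units; within the scatter) and so shows that, in this pair, the oxygen on the carbonyl carbon can go, together with the nitrile, with no change beyond the scatter. The fluorinated carbamates place this amide differently, with a 2.4-fold lower number from compound 3 to compound 4 (0.39 log units; beyond the scatter) on one side and a 3.8-fold higher number from compound 2 to compound 4 (0.58 log units; beyond the scatter) on the other, so compound 2 keeps the lowest number of the four. Nothing shown here gives a reason for these differences.

The compounds shown leave open whether a 1-(fluoromethyl)-1-methylethyl group set directly on the carbonyl carbon would reach the number of compound 2. They also leave open how a trifluoromethyl group in place of the fluorine of compound 4 would read.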